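A few compounds are considered here, and "the series" means these few. Any claim that something is new, unique, unknown or untested is made for them only; others in the source may bear on it.

Working notes on the series. Compound 1 `O=C(CCN1CCC(c2nc(-c3ccccn3)no2)CC1)NC(c1ccc(Cl)cc1)c1ccc(Cl)cc1` gives in an assay on isolated protein for inhibition of lysosomal Pro-X carboxypeptidase (Mus musculus), read by fluorescence, with a stated time of 30 min (a higher number here means a weaker inhibitor, a lower number a stronger inhibitor), a value of 10 nM. For the measured compounds named here, compound 2 `O=C(CCN1CCC(c2ccccc2)CC1)NC(c1ccc(Cl)cc1)c1ccc(Cl)cc1` gives in this assay a value of 4 nM, the lower of the two numbers so far; the only step in hand is a 2.5-fold lower number from compound 1 to compound 2 (0.40 log units; beyond the scatter), a change on the saturated ring of the shared core.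

Compound 3 `O=C(CCN1CCC(c2ccccc2)CC1)NC(c1ccncc1)c1ccc(Cl)cc1` is not yet measured. It differs from compound 2 by pyridin-4-yl in place of 4-chlorophenyl on a saturated chain carbon bound to an amide-type nitrogen and an aromatic carbon. Going by the values given here, no measured step touches this part of the shared core, so the step from compound 1 to compound 2 does not bear on it, and there is nothing in hand to set the direction. The expectation is therefore a modest step in this assay, with a wide range. For compound 3 the estimated value in this assay is 10 nM, with a range from 3 nM to 40 nM. This estimate means an expected step of a 2.5-fold higher number from compound 2 to compound 3 (0.40 log units; beyond the scatter).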

Compound 3, half-maximal inhibitory concentration: 2.1 nM
Estimate against measurement, compound 3: 4.8-fold (0.68 log units) above, outside the stated range (below it).
By their numbers in this assay, from the lowest: compounds 3 and 2 (each within the scatter of the next); then compound 1.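

At the saturated chain carbon bound to an amide-type nitrogen and an aromatic carbon, pyridin-4-yl in place of 4-chlorophenyl gives a 1.9-fold lower number from compound 2 to compound 3 (0.28 log units; within the scatter) in this assay. For the compounds shown here, this is the first reading at this position, and it shows that one 4-chlorophenyl can be exchanged for a ring carrying a hydrogen-bond acceptor and no chlorine with no change that can be told from the scatter. Nothing in hand explains this result.

Open, on these data alone, is whether the second 4-chlorophenyl on the same carbon accepts the same exchange, and whether pyridin-4-yl behaves alike with the 3-(pyridin-2-yl)-1,2,4-oxadiazol-5-yl group of compound 1. Also open, as far as these compounds go, is how pyridin-3-yl, or a phenyl bearing a carboxylic acid or an aminomethyl group, would read at this position.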